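This account rests on a few compounds, and the source may have more. Where it says the series, first, only, none or still open, it means among the compounds named here.

Measured so far in a functional assay on A549 cells (Homo sapiens) for inhibition, read by sulforhodamine B assay, with a stated time of 48 h; a lower number here means a stronger inhibitor, a higher number a weaker inhibitor:
- Compound 1 `CCO[C@H]1C[C@@H](c2coc3ccccc3c2=O)N(c2ccccc2)O1`: > 60000 nM, a limit of the assay and not a number
- Compound 2 `CCO[C@H]1C[C@@H](c2coc3ccc(F)cc3c2=O)N(c2ccccc2)O1`: 26400 nM
- Compound 3 `O=c1c([C@@H]2C[C@H](c3ccccc3)ON2c2ccccc2)coc2ccc(Br)cc12`: 51000 nM

Compound 3, at 51000 nM, sits within the usual scatter of compound 2, at 26400 nM, so these two values cannot be told apart.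

The next compound is compound 4 `CCO[C@H]1C[C@@H](c2coc3ccc(Br)cc3c2=O)N(c2ccccc2)O1`. Going to it from compound 3, the change is ethoxy in place of phenyl on a saturated ring carbon.

Among the compounds with values here, no measured step covers this swap. Within the data shown here, the one measured step is an at least 2.2-fold lower number from compound 1 to compound 2 (0.35 log units; beyond the scatter), with fluoro in place of hydrogen on an aromatic carbon. It rests on (the limit of > 60000 nM in this assay, at which 1 of the 3 values shown sits), so its size is only a bound, and it bears on this swap only indirectly.

The best guide is compound 2 at 26400 nM, which has the same ethoxy group as compound 4 and also carries a halogen. No step beyond the scatter is therefore expected in this assay.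

The expected change is a 1.6-fold lower number from compound 3 to compound 4 (0.20 log units; within the scatter).

For compound 4 the estimate is 32000 nM, with an expected range from 13000 nM to 60000 nM.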

Compound 4, half-maximal inhibitory concentration: 21500 nM
Compound 4: middle estimate off by 1.5-fold (0.17 log units), on the high side; the range from low to high includes it.
By their numbers in this assay, from the lowest: compounds 4, 2 and 3 (each within the scatter of the next, the first and the last beyond it). At a limit, above all of these: compound 1.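

Within the data shown here, this is the first measured swap at the saturated ring carbon next to the ring oxygen, and with bromo held in place it goes beyond the scatter in this assay (a 2.4-fold lower number from compound 3 to compound 4 (0.38 log units; beyond the scatter)). With ethoxy on that carbon, bromo and fluoro on the aromatic carbon cannot be told apart (a 1.2-fold lower number from compound 2 to compound 4 (0.09 log units; within the scatter)). Bromo in place of hydrogen gives a further step (an at least 2.7-fold lower number from compound 1 to compound 4 (0.44 log units; beyond the scatter)), but its size is only a bound, since the value for compound 1 is a limit of the assay and not a number: the limit of > 60000 nM in this assay, at which 1 of the 4 values shown sits.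

The compounds shown leave open how an amine, a methoxy or a longer alkoxy chain would read on the saturated ring carbon. They also leave open whether the swap from phenyl to ethoxy gives a similar step with fluoro or hydrogen on the aromatic carbon.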